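A few compounds are considered here, and "the series" means these few. Any claim that something is new, unique, unknown or untested is made for them only; others in the source may bear on it.

In a functional assay on MIA PaCa-2 cells (Homo sapiens) for inhibition, read by MTT assay, with a stated time of 48 h, tested at 10 uM (on this read-out higher numbers stand for more inhibition of growth at the one concentration tested and lower numbers for less inhibition of growth), compound 1 `Cc1oc2c([C@H]3CCN(C)C[C@H]3O)c(O)cc(O)c2c(=O)c1C(O)c1cccc(Cl)c1` gives 2% and compound 2 `Cc1oc2c([C@H]3CCN(C)C[C@H]3O)c(O)cc(O)c2c(=O)c1C(O)c1ccccc1Br` gives 10% so compound 2 cannot be told apart from compound 1. Compound 3 `Cc1oc2c([C@H]3CCN(C)C[C@H]3O)c(O)cc(O)c2c(=O)c1C(O)c1ccc(F)c(Br)c1` is related to compound 2 by 3-bromo-4-fluorophenyl in place of 2-bromophenyl on a saturated chain carbon bound to an aromatic carbon and an oxygen on a saturated carbon and the new phenyl group stays on a saturated chain carbon bound to an aromatic carbon and an oxygen on a saturated carbon. Among the measured compounds shown here, only one measured step bears on this, a phenyl exchange at the same place that came out as a number 8 percentage points higher from compound 1 to compound 2 (within the scatter) and so no step beyond the scatter is expected in this assay here. The estimated change is a number 2 percentage points lower from compound 2 to compound 3 (within the scatter) on these grounds. For compound 3 the expected value is 8% with an estimated range from 0% to 24% in repeat measurements.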

Compound 3, percent growth inhibition at one concentration: 9%
The estimate for compound 3 lay 1 percentage points below the measured number; the measured number falls inside the stated range.
By their numbers in this assay, from the lowest: compounds 1, 3 and 2 (each within the scatter of the next).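

At the saturated chain carbon bound to an aromatic carbon and an oxygen on a saturated carbon, a third phenyl group, 3-bromo-4-fluorophenyl, brings no step beyond the scatter in this assay, with a number 1 percentage points lower from compound 2 to compound 3 (within the scatter) and a number 7 percentage points higher from compound 1 to compound 3 (within the scatter) at this position. The three halogen-bearing phenyl groups thus cannot be told apart here, even with a second halogen on the ring. No evidence on the cause of this is at hand.

Open, going by these compounds, is whether an aminophenyl group or a carboxylic acid at this place would move the number beyond the scatter.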